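The source may hold more compounds than are shown below. What is called first, only, known or untested is meant among the compounds shown, and "the series" means these compounds.

Three ureas share one core and differ only in the group on one aromatic ring. Compound 1 `CCc1ccc(NC(=O)Nc2c(C(C)C)cccc2C(C)C)cc1` carries an ethyl group, and in an assay on isolated protein for inhibition of acyl-CoA:cholesterol acyltransferase (Oryctolagus cuniculus) (a higher number here means a weaker inhibitor, a lower number a stronger inhibitor), compound 1 gives 100 nM. Compound 2 `CCCCCCCc1ccc(NC(=O)Nc2c(C(C)C)cccc2C(C)C)cc1` carries a heptyl chain, and in this assay compound 2 gives 19 nM. Compound 3 `CC(C)c1cccc(C(C)C)c1NC(=O)Nc1ccc(C(C)(C)C)cc1` carries a tert-butyl group; in this assay compound 3 gives 168 nM, the highest of the three numbers. Compound 4 `CCCCCCCCCCc1ccc(NC(=O)Nc2c(C(C)C)cccc2C(C)C)cc1` is not yet measured and differs from compound 3 by decyl in place of tert-butyl on an aromatic carbon. Among the measured compounds shown here, two measured steps bear on this change: a longer chain gave a 5.3-fold lower number from compound 1 to compound 2 (0.72 log units; beyond the scatter), and replacing the chain by tert-butyl gave an 8.8-fold higher number from compound 2 to compound 3 (0.95 log units; beyond the scatter), while a 1.7-fold higher number from compound 1 to compound 3 (0.23 log units; within the scatter) was small. Because compound 2 with its heptyl chain gives 19 nM, a decyl chain on compound 4 is expected to bring a step of about an 11-fold lower number from compound 3 to compound 4 (1.05 log units; beyond the scatter). Compound 4 is therefore estimated at 15 nM in this assay, expected between 6 nM and 45 nM.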

Compound 4, half-maximal inhibitory concentration: 13 nM
Compound 4: the middle estimate sits 1.2-fold (0.06 log units) above what was measured, within the range that was stated.
By their numbers in this assay, from the lowest: compounds 4 and 2 (each within the scatter of the next); then compounds 1 and 3 (each within the scatter of the next).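

In this assay the step from heptyl to decyl is a 1.5-fold lower number from compound 2 to compound 4 (0.16 log units; within the scatter), so these two long chains cannot be told apart, and the improvement seen on going from ethyl to heptyl does not clearly continue at decyl. The decyl chain still stands well clear of the shorter groups, with a 7.7-fold lower number from compound 1 to compound 4 (0.89 log units; beyond the scatter) starting from ethyl and a 13-fold lower number from compound 3 to compound 4 (1.11 log units; beyond the scatter) starting from tert-butyl, the largest step among these compounds. Nothing measured here explains why chain length matters at this position.

The compounds shown leave open whether a chain longer than decyl would keep this level or lose it. They also leave open how a chain ending in a carboxylic acid or an amine would behave at this position.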